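Swapping the nitro-bearing ring for a chlorine-bearing one

A few compounds are considered here, and "the series" means these few. Any claim that something is new, unique, unknown or untested is made for them only; others in the source may bear on it.

Of the compounds shown here, two from this series have been measured in an assay on HEK293 cells for displacement of a labelled ligand from Melanocortin receptor 4 (Homo sapiens); a higher number here means a weaker inhibitor, a lower number a stronger inhibitor. Compound 1 `CC(C)C[C@H](N)c1cc(C(F)(F)F)ccc1N1CCN(C(=O)[C@H](C)Cc2ccc(Cl)cc2)CC1` gives 31 nM in this assay. Within the data shown here, compound 2 `CC(C)C[C@H](N)c1cc(C(F)(F)F)ccc1N1CCN(C(=O)COc2ccc([N+](=O)[O-])cc2)CC1` gives 3100 nM in this assay, the highest number of the two; its only neighbour is compound 1, and the gap between them is large, a 100-fold higher number from compound 1 to compound 2 (2.00 log units; beyond the scatter). Compound 3 `CC(C)C[C@H](N)c1cc(C(F)(F)F)ccc1N1CCN(C(=O)COc2cccc(Cl)c2)CC1` has not yet been measured. It differs from compound 2 in one place: 3-chlorophenyl in place of 4-nitrophenyl on an oxygen on a saturated carbon.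

Among the measured compounds shown here, only one measured step exists, and it bears on this change indirectly: from compound 1 to compound 2 both the link to the carbonyl and the aromatic ring changed together, and the number rose steeply. Compound 3 keeps the phenoxymethyl link of compound 2 and carries a chlorine on its ring, as compound 1 does. For the measured compounds named here, the data give no step in which only the ring substituent moves, so the expected size is uncertain; a moderate fall in the number is estimated, a 3.1-fold lower number from compound 2 to compound 3 (0.49 log units; beyond the scatter). Compound 3 is expected to give about 1000 nM in this assay, within a range from 200 nM to 5000 nM.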

Compound 3, inhibition constant: 2600 nM
For compound 3 the middle estimate is 2.6-fold (0.41 log units) below the measured one, and the stated range covers the measured number.
By their numbers in this assay, from the lowest: compound 1; then compounds 3 and 2 (each within the scatter of the next).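

In this assay, putting 3-chlorophenyl in place of 4-nitrophenyl on the oxygen gives a 1.2-fold lower number from compound 2 to compound 3 (0.08 log units; within the scatter) and so leaves the two compounds indistinguishable, which means that at this position the two rings cannot be told apart by this read-out. Placing (3-chlorophenoxy)methyl on the carbonyl carbon instead of 1-(4-chlorobenzyl)ethyl gives an 84-fold higher number from compound 1 to compound 3 (1.92 log units; beyond the scatter) and shows that a chlorine-bearing ring on the phenoxymethyl link does not bring the number close to that of compound 1, so the large gap remains even when both compounds carry a chlorine. Nothing available here explains why the ring exchange on the oxygen leaves the number within the scatter, or why the exchange on the carbonyl carbon opens so large a gap.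

On these data alone, the ring substituent and its place on the ring changed together between compound 2 and compound 3, so it remains open whether 4-chlorophenyl on that oxygen, or a ring carrying a methoxy group or a nitrile, would read the same. Also open is which feature of the 1-(4-chlorobenzyl)ethyl group matters most, since a plain 4-chlorophenoxymethyl or a straight 2-(4-chlorophenyl)ethyl chain is not among the compounds shown.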